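Adding One Methyl to the Chain of Compound 3

The compounds below may be only part of what the source reports. "The series", "measured", "known", "first", "only" and "open" are said of these compounds alone.

Of the compounds shown here, three sharing one core have been tested in a functional assay on HEL cells (Homo sapiens), read by microscopy; a higher number here means that more compound is tolerated, a lower number that less compound is tolerated. Compound 1, `CCCCCCCCCCc1cc2cn(COCCO)c(O)nc-2n1`, gives 80000 nM in this assay. Compound 2, `CCCCCCCc1cc2cn(COCCO)c(O)nc-2n1`, gives >= 400000 nM in this assay, which is a limit of the assay rather than a number. Compound 3, `CCCCc1cc2cn(COCCO)c(O)nc-2n1`, gives > 400000 nM in this assay, again a limit rather than a number, so compound 3 stands at the top of what this assay reports (the limit of > 400000 nM in this assay, at which 1 of the 3 values shown sits).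

Compound 4, `CCCCCc1cc2cn(COCCO)c(O)nc-2n1`, is the next compound to be measured. It differs from compound 3 by methyl in place of hydrogen on a saturated chain carbon, four bonds along the chain from an aromatic carbon. The measured steps run in the opposite direction, shortening the chain: hydrogen in place of hexyl gives an at least 5.0-fold higher number from compound 1 to compound 3 (0.69 log units; beyond the scatter), hydrogen in place of propyl gives an at least 5.0-fold higher number from compound 1 to compound 2 (0.69 log units; beyond the scatter), and a step that the two limits leave unreadable from compound 2 to compound 3 cannot be read from the two limits. Lengthening the chain by one methyl would therefore be expected to move the number downward, if at all, and compound 2 with its longer chain still sits at a limit (the limit of >= 400000 nM in this assay, at which 1 of the 3 values shown sits).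

Compound 4 is therefore estimated at 400000 nM in this assay, between 150000 nM and 800000 nM. The expected step is a number no higher from compound 3 to compound 4 (the limit leaves the size open), most likely again reported only as a limit.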

Compound 4, minimum cytotoxic concentration: > 400000 nM
Compound 4: only a limit was reported (the forecaster's own chance of this, stated with the estimate: 70%); the middle value lies on the limit itself.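

In this assay compound 4 gives > 400000 nM, which is a limit of the assay and not a number, so adding one methyl to the chain of compound 3 brings no fall in the tolerated concentration into view, and compound 4 shares the top of what is reported: the limit of > 400000 nM in this assay, at which 2 of the 4 values shown sit.

Among these compounds, the contrast with the longest chain is still clear, with an at least 5.0-fold higher number from compound 1 to compound 4 (0.69 log units; beyond the scatter), which leaves compound 1 as the only one of the four compounds with a reported number rather than a limit. Both ends of the steps from compound 3 and from compound 2 to compound 4 are limits, and those steps cannot be read.

From the compounds shown here alone, the true tolerated concentrations of the shorter chains remain unknown, and so does the point along the chain, somewhere past the length in compound 2, at which a measurable number first appears. An octyl chain could help to narrow that point, while an amine at the end of the chain would show whether this position responds to anything other than added carbon.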